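Changing the amide side chain of compound 2

This account rests on a few compounds, and the source may have more. Where it says the series, first, only, none or still open, it means among the compounds named here.

Compound 1 `O=C(CO[N+](=O)[O-])Nc1ccc(C(=O)/C=C/c2ccc(Cl)cc2)cc1`: 67%
Compound 2 `O=C(CO[N+](=O)[O-])Nc1ccc(C(=O)/C=C/c2ccco2)cc1`: 40%

In a functional assay on the whole organism (strain albino) for inhibition, with Rattus norvegicus as the target, read by paw edema, with stated times of 30 min and 4 h, at a dose of 100 mg/kg by the oral route (on this read-out lower numbers stand for less inhibition and higher numbers for more inhibition at the one dose given (going by the name of the read-out)), compound 2 gives 40%, the lowest of the two numbers, and compound 1 gives 67%, the step of a number 27 percentage points lower from compound 1 to compound 2 (beyond the scatter) lying beyond the scatter. Compound 3 `CC(Br)C(=O)Nc1ccc(C(=O)/C=C/c2ccco2)cc1` differs from compound 2 on the carbonyl carbon bound to the amide-type nitrogen: 1-bromoethyl in place of (nitrooxy)methyl on a carbonyl carbon. Going by the values given here, no measured step touches that carbonyl; the only known step concerns the group on the double-bonded chain carbon and says nothing about this change. The expected step of no change at the digits printed from compound 2 to compound 3 (within the scatter) is therefore set at none beyond the scatter. Compound 3 is estimated at 40%, within 20% to 60%.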

Compound 3, a percentage reported as inhibition, in the whole organism at one dose (the size of the read-out at that dose, not a potency): 36%
For compound 3 the middle estimate is 4 percentage points above the measured one; the measured number falls inside the stated range.
By their numbers in this assay, from the lowest: compounds 3 and 2 (each within the scatter of the next); then compound 1.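

In this assay, going by these compounds alone, the exchange of (nitrooxy)methyl for 1-bromoethyl on a carbonyl carbon gives a number 4 percentage points lower from compound 2 to compound 3 (within the scatter) and is the first measured change at this place. With furan-2-yl in the molecule, the read-out therefore does not depend on keeping the nitrooxy group, since a chain with no hydrogen-bond acceptors serves within the scatter. No available evidence bears on this result. From the compounds shown here alone, whether the same holds alongside the 4-chlorophenyl of compound 1 stays open. So does the outcome with an amine or a carboxylic acid on that carbonyl carbon.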